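Removing the 3-methoxy from the N-acetyl series

The compounds below may be only part of what the source reports. "The series", "measured", "known", "first", "only" and "open" are said of these compounds alone.

Compound 3 `COc1ccc(/C(=C\c2cn(C(C)=O)c3ccc(OCc4ccccc4)cc23)C(=O)O)cc1OC` gives, in a functional assay on M14 cells (Homo sapiens) for cytotoxicity, read by MTT assay, with a stated time of 72 h (on this read-out lower numbers stand for stronger inhibition and higher numbers for weaker inhibition), a half-maximal inhibitory concentration of 65500 nM. Among the numbers shown it stands highest of two; compound 1 `COc1ccc(/C(=C\c2c[nH]c3ccc(OCc4ccccc4)cc23)C(=O)O)cc1` gives 58400 nM in this assay, a gap from compound 3 that lies within the scatter. Compound 2 `COc1ccccc1/C(=C\c1cn(C(C)=O)c2ccc(OCc3ccccc3)cc12)C(=O)O` reaches only a limit of this assay, > 100000 nM, and no number. That limit is the point where one of the three shown values sits (the limit of > 100000 nM in this assay, at which 1 of the 3 values shown sits).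

Compound 4 `COc1ccc(/C(=C\c2cn(C(C)=O)c3ccc(OCc4ccccc4)cc23)C(=O)O)cc1` differs from compound 3 by hydrogen in place of methoxy on an aromatic carbon. For the measured compounds named here, the one measured step that touches the methoxy pattern on this phenyl is an at least 1.5-fold lower number from compound 2 to compound 3 (0.18 log units; that floor lies within the scatter), which reaches only from a limit to a number and is itself small. Compound 1 carries the same 4-methoxyphenyl as compound 4 on a core without the acetyl and sits close to compound 3, so there is no measured ground for expecting a step beyond the scatter.

Compound 4 is therefore expected to land near compound 3, with a 1.1-fold higher number from compound 3 to compound 4 (0.03 log units; within the scatter) as the estimated step, giving an expected value of 70000 nM with a range of 35000 nM to 140000 nM in this assay.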

Compound 4, half-maximal inhibitory concentration: > 100000 nM
Compound 4: a limit, no number; the forecaster's own chance of this, stated with the estimate: 35%; at least 1.4-fold (0.15 log units) between middle value and limit.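

Compound 4 gives only a limit in this assay, > 100000 nM, so hydrogen in place of methoxy on this aromatic carbon, ortho to a methoxy group, turns a measured number into a limit, with an at least 1.5-fold higher number from compound 3 to compound 4 (0.18 log units; that floor lies within the scatter). For the compounds shown here, the same compound gives the first reading of the acetyl on its own, hydrogen on the aromatic nitrogen giving way to acetyl with an at least 1.7-fold higher number from compound 1 to compound 4 (0.23 log units; that floor lies within the scatter); both readings are floors, so neither establishes a step beyond the scatter, though each pair now has a number on one side and a limit on the other. The step between the 2-methoxyphenyl and 4-methoxyphenyl compounds cannot be read, as both values are limits, and the N-acetyl series now holds two compounds at that ceiling: the limit of > 100000 nM in this assay, at which 2 of the 4 values shown sit.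

From the compounds shown here alone, the true size of both readable steps stays open, since each rests on a limit and could lie anywhere from within the scatter upward. Also open, going by these compounds, is whether a hydroxyl or an amine in place of the methoxy on this aromatic carbon would keep a number in this assay.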